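The compounds below may be only part of what the source reports. "The series", "measured", "known", "first", "only" and "open" are said of these compounds alone.

Working notes on the series. In a functional assay on a subcellular fraction from brain (Rattus norvegicus) for inhibition, read by scintillation counting, with a stated time of 5 min (on this read-out higher numbers stand for weaker inhibition and lower numbers for stronger inhibition), compound 1 `CCc1ccc(NC2=NCCC3(CCCCC3)S2)cc1` gives 11700 nM, and compound 2 `Cc1cccc(C(C)C)c1NC1=NCCC2(CCCCC2)S1` gives 20900 nM; the two numbers fall within the usual scatter of each other, so neither compound can be set ahead of the other on what is shown. Compound 3 `Cc1ccc(NC2=NCCC3(CCCCC3)S2)cc1` is not yet measured in this assay. It differs from compound 1 by hydrogen in place of methyl on a saturated chain carbon bound to an aromatic carbon. Among the compounds with values here, no measured pair shows what this change does, so the expected step from compound 1 to compound 3 in this assay, a 1.3-fold higher number from compound 1 to compound 3 (0.11 log units; within the scatter), is one of no more than the scatter, in no firm direction. Compound 3 is therefore estimated at 15000 nM, in a range from 6000 nM to 40000 nM.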

Compound 3, half-maximal inhibitory concentration: 31600 nM
The estimate for compound 3 lay 2.1-fold (0.32 log units) below the measured number, within the range that was stated.
By their numbers in this assay, from the lowest: compounds 1, 2 and 3 (each within the scatter of the next, the first and the last beyond it).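

In this assay, within the data shown here, the change from ethyl to methyl gives a 2.7-fold higher number from compound 1 to compound 3 (0.43 log units; beyond the scatter) and is the only step so far that can be read. It shows that this position responds to the loss of a single methyl on a saturated chain carbon bound to an aromatic carbon, with weaker inhibition for the shorter group. No evidence at hand bears on the reason for this step. With only ethyl and methyl compared here, the trend does not extend to a longer chain such as propyl. As far as these compounds go, whether an amine or a carboxylic acid at this place would be tolerated also remains open.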